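Curcumin-type conjugates: removing a methoxy group

A few compounds are considered here, and "the series" means these few. Any claim that something is new, unique, unknown or untested is made for them only; others in the source may bear on it.

Compound 1 `COc1cc(/C=C/C(=O)/C=C(O)/C=C/c2ccc(O[C@]3(C)C=C[C@@H]([C@@H](C)CC(=O)C=C(C)C)C[C@@H]3O)c(OC)c2)ccc1O` and compound 2 `COc1cc(/C=C/C(=O)/C=C(O)/C=C/c2ccc(O[C@]3(C)C=C[C@@H]([C@@H](C)CC(=O)C=C(C)C)C[C@@H]3O)cc2)ccc1O` share one core, while compound 3 `COc1cc(/C=C/C(=O)/C=C(O)/C=C/c2ccc(O[C@H]3C=C(C)[C@@H](O)C[C@@H]3[C@@H](C)CC(=O)C=C(C)C)c(OC)c2)ccc1O` is built on a core that differs from it in a way not broken down here. In a functional assay on MDA-MB-231 cells (Homo sapiens) for cytotoxicity, read by crystal violet staining, with a stated time of 72 h (a lower number here means a stronger inhibitor, a higher number a weaker inhibitor), compound 1 gives 19400 nM and compound 2 gives 15900 nM, so that a 1.2-fold lower number from compound 1 to compound 2 (0.09 log units; within the scatter) when hydrogen in place of methoxy on an aromatic carbon is made. Compound 3 gives 10600 nM in this assay. Compound 4 `COc1cc(/C=C/C(O)=C/C(=O)/C=C/c2ccc(O)cc2)ccc1O[C@H]1C=C(C)[C@@H](O)C[C@@H]1[C@@H](C)CC(=O)C=C(C)C` has not yet been measured; it arises from compound 3 through (hydrogen in place of methoxy on an aromatic carbon). This is the same kind of change as that from compound 1 to compound 2, though the place differs: ortho to a hydroxy group (1 heavy atom) rather than ortho to a large group. Because the earlier change gave a 1.2-fold lower number from compound 1 to compound 2 (0.09 log units; within the scatter), the step is expected to be a 1.1-fold lower number from compound 3 to compound 4 (0.05 log units; within the scatter). Compound 4 is therefore estimated at 9500 nM, between 4500 nM and 20000 nM.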

Compound 4, half-maximal inhibitory concentration: 10300 nM
The estimate for compound 4 lay 1.1-fold (0.04 log units) below the measured number; measured number inside the range.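

In this assay, hydrogen in place of methoxy on the core of compound 3 gave a 1.0-fold lower number from compound 3 to compound 4 (0.01 log units; within the scatter). The change behaved alike on the two cores, with no difference beyond the scatter: the same change on two cores in this assay, a 1.2-fold lower number (0.09 log units; within the scatter) from compound 1 to compound 2 and a 1.0-fold lower number (0.01 log units; within the scatter) from compound 3 to compound 4, 1.2-fold (0.07 log units) apart, within the scatter of two such steps. Among the compounds shown here, this shows only that the step was small in both pairs; it does not establish a rule for the whole series, as there are just two pairs, and the methoxy left ortho to a hydroxy group in one pair but ortho to a large group in the other.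

Only methoxy and hydrogen are compared at these places. As far as these compounds go, whether a fluorine, an amine or a longer alkoxy chain there would shift the number, and whether it would do so equally on both cores, remains open.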